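The compounds below may be only part of what the source reports. "The series", "measured", "known", "first", "only" and "open" are said of these compounds alone.

Compound 1 `O=C1COc2ccc(-c3cccc(NS(=O)(=O)c4ccc(F)cc4)c3)cc2N1`: 20100 nM
Compound 2 `COc1ccc(N2C(=O)COc3ccc(-c4cccc(NS(=O)(=O)c5ccc(F)cc5)c4)cc32)cc1`: 38500 nM

Both values come from a functional assay on A-375 cells (Homo sapiens) for antiproliferative activity, read by MTT assay, with a stated time of 72 h (a higher number here means a weaker inhibitor, a lower number a stronger inhibitor), and lie within the scatter of each other, so the numbers do not separate compound 2 from compound 1. Compound 3 `O=C1COc2ccc(-c3cccc(NS(=O)(=O)c4ccc(F)cc4)c3)cc2N1c1ccc(F)cc1` keeps the rest of compound 2 and changes one group, 4-methoxyphenyl to 4-fluorophenyl, with fluoro in place of methoxy on an aromatic carbon, para to a large group: fluoro in place of methoxy on an aromatic carbon. Among the compounds with values here, no measured pair makes this swap directly. The closest evidence is the step that added the whole 4-methoxyphenyl on an amide-type nitrogen, a 1.9-fold higher number from compound 1 to compound 2 (0.28 log units; within the scatter), which gives no sign of a large effect. No step beyond the scatter is therefore expected here. The expected outcome is a 1.3-fold lower number from compound 2 to compound 3 (0.11 log units; within the scatter) for this swap. Compound 3 is expected at 30000 nM with an estimated range of 14000 nM to 62000 nM in this assay.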

Compound 3, half-maximal inhibitory concentration: > 40000 nM
Compound 3 gave a limit, no number (the forecaster's own chance of this, stated with the estimate: 10%); at least 1.3-fold (0.12 log units) between middle value and limit.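

In this assay compound 3 gives a limit of the assay and not a number: the limit of > 40000 nM in this assay, at which 1 of the 3 values shown sits. As far as these compounds go, the steps can therefore be read only as floors, an at least 1.0-fold higher number from compound 2 to compound 3 (0.01 log units; that floor lies within the scatter) and an at least 1.9-fold higher number from compound 1 to compound 3 (0.29 log units; that floor lies within the scatter), and both floors lie within the scatter, so how far compound 3 really lies from either compound stays unknown. What is new is that fluoro in place of methoxy on the aromatic carbon, para to a large group, gives no sign of a stronger inhibitor, and neither aromatic group on the amide-type nitrogen shows a gain over the hydrogen of compound 1.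

Still open, from the compounds shown here alone, is how an amine or a carboxylic acid would read at this same aromatic carbon. Going by these compounds, a small methyl on the amide-type nitrogen, in place of the whole aromatic ring, is equally open.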